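Swapping the Carbamate Cap of Compound 2

This account rests on a few compounds, and the source may have more. Where it says the series, first, only, none or still open, it means among the compounds named here.

Three compounds sharing one core were measured in a functional assay on isolated protein for agonist activity at Glucose-dependent insulinotropic receptor (Rattus norvegicus), read by HTRF and cAMP accumulation; a higher number here means that more compound is needed for the effect, a lower number that less compound is needed. Compound 1 `CC(C)(C)OC(=O)N1CCC(O[C@H]2CC[C@H](Oc3ccc(S(C)(=O)=O)cc3)CC2)CC1` gives 94 nM. Compound 2 `CC(C)(C)OC(=O)N1CCC(O[C@H]2CC[C@H](Oc3cnc(S(C)(=O)=O)cn3)CC2)CC1` gives 64 nM, and compound 3 `CC(C)(C)OC(=O)N1CCC(O[C@H]2CC[C@H](Oc3ccc(S(C)(=O)=O)nn3)CC2)CC1` gives 1160 nM. Compound 2 has the lowest of the three numbers, yet the step of a 1.5-fold lower number from compound 1 to compound 2 (0.17 log units; within the scatter) lies within the scatter, so compound 1 and compound 2 cannot be told apart on these data. The steps of a 12-fold higher number from compound 1 to compound 3 (1.09 log units; beyond the scatter) and an 18-fold higher number from compound 2 to compound 3 (1.26 log units; beyond the scatter) are large and clearly beyond the scatter, and both come from exchanging the aryl group on the oxygen on a saturated carbon.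

Compound 4 `CS(=O)(=O)c1cnc(O[C@H]2CC[C@H](OC3CCN(C(=O)OC4CCOC4)CC3)CC2)cn1` keeps the aryl group of compound 2 and changes the opposite end of the molecule: oxolan-3-yl in place of tert-butyl on an oxygen next to a carbonyl group. None of the three measured steps touches this place; every one of them varies the aryl group. Going by the values given here, there is thus no measured step that bears directly on the change from compound 2 to compound 4, and the only guide is that the part of the molecule which produced the large steps stays unchanged. The expectation for compound 4 is therefore a step of a 1.4-fold higher number from compound 2 to compound 4 (0.15 log units; within the scatter), that is, no change beyond the scatter in this assay. Compound 4 is estimated at 90 nM, with a range from 30 nM to 300 nM.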

Compound 4, half-maximal effective concentration: 1500 nM
Compound 4: middle estimate off by 17-fold (1.22 log units), on the low side; the measured number lies above the stated range.
By their numbers in this assay, from the lowest: compounds 2 and 1 (each within the scatter of the next); then compounds 3 and 4 (each within the scatter of the next).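

In this assay, the earlier large steps all came from exchanging the aryl group, and this result shows that the opposite end of the molecule can produce a large step too. Going by these compounds alone, with the aryl group of compound 2 left untouched, oxolan-3-yl in place of tert-butyl on an oxygen next to a carbonyl group brings a 23-fold higher number from compound 2 to compound 4 (1.37 log units; beyond the scatter) as the only change in structure. The exchange replaces a group of four carbons with no ring by a five-membered non-aromatic ring that holds one oxygen and one hydrogen-bond acceptor, but no measurement at hand says what lies behind the step.

The compounds shown leave open whether the step follows from the ring itself or from the oxygen in it, a question that a cyclopentyl group, with a five-membered ring and no oxygen, would help to settle. They also leave open whether oxolan-3-yl in place of tert-butyl would bring a step of similar size when the aryl group is the 4-(methylsulfonyl)phenyl of compound 1.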